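Swapping methoxy for chloro on the phenylpiperazine arm

The source may hold more compounds than are shown below. What is called first, only, known or untested is meant among the compounds shown, and "the series" means these compounds.

Three measured compounds share one core and differ only in the group on a phenyl ring attached to a piperazine nitrogen. Compound 1 `O=C(CN1CCN(c2ccccc2)CC1)N1CCN(c2nnc(-c3ccccc3)c(-c3ccccc3)n2)CC1` carries that ring unsubstituted. In a functional assay on MCF7 cells (Homo sapiens) for cytotoxicity, read by MTT assay, with a stated time of 24 h (a higher number here means a weaker inhibitor, a lower number a stronger inhibitor), compound 1 gives a value that is a limit of the assay, > 963000 nM. Compound 2 `O=C(CN1CCN(c2ccccc2Cl)CC1)N1CCN(c2nnc(-c3ccccc3)c(-c3ccccc3)n2)CC1` adds a chloro, and in this assay compound 2 gives 263000 nM. Compound 3 `COc1cccc(N2CCN(CC(=O)N3CCN(c4nnc(-c5ccccc5)c(-c5ccccc5)n4)CC3)CC2)c1` carries a methoxy instead. In this assay compound 3 gives only a limit, > 910000 nM. Compound 3 therefore stands at the top of the scale that the assay can read: an at least 3.4-fold higher number from compound 2 to compound 3 (0.53 log units; beyond the scatter), while a step that the two limits leave unreadable from compound 1 to compound 3.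

Compound 4 `O=C(CN1CCN(c2cccc(Cl)c2)CC1)N1CCN(c2nnc(-c3ccccc3)c(-c3ccccc3)n2)CC1` is compound 3 with a single change: chloro in place of methoxy on an aromatic carbon. Within the data shown here, two measured steps bear on it. First, an at least 3.6-fold lower number from compound 1 to compound 2 (0.56 log units; beyond the scatter). Second, an at least 3.4-fold higher number from compound 2 to compound 3 (0.53 log units; beyond the scatter). Both point the same way, toward a lower number with chloro than with hydrogen or methoxy, though compound 2 carries a 2-chlorophenyl and compound 4 a 3-chlorophenyl, so the match is not exact.

A modest step down is therefore expected, an at least 2.2-fold lower number from compound 3 to compound 4 (0.35 log units; beyond the scatter), with a real chance that the assay again reports only a limit. Compound 4 is estimated at 400000 nM, within a range from 150000 nM to 1000000 nM.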

Compound 4, half-maximal inhibitory concentration: 56300 nM
Beside the measured number, compound 4's estimate is 7.1-fold (0.85 log units) above it; measured number outside the range, below it.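

In this assay, keeping the position fixed and swapping only the group gives an at least 16-fold lower number from compound 3 to compound 4 (1.20 log units; beyond the scatter), so the choice between methoxy and chloro matters a great deal at this place on the ring, meta to a large group. Set against the bare ring, the same chloro gives an at least 17-fold lower number from compound 1 to compound 4 (1.23 log units; beyond the scatter), and set against the 2-chlorophenyl, the 3-chlorophenyl gives a 4.7-fold lower number from compound 2 to compound 4 (0.67 log units; beyond the scatter), so where the chloro sits counts as well as whether it is present, something the earlier compounds could not show. Compound 3 stands at a limit of the assay, which means that the true size of its step stays unread: the limit of > 910000 nM in this assay, at which 1 of the 4 values shown sits.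

The compounds shown leave open whether chloro itself is what matters at this place, or whether a bromo, a trifluoromethyl or a nitrile there would bring the number lower still. They also leave open whether a second chloro on the same ring would add to the step, and whether an amine or a carboxylic acid would be tolerated at this place at all.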